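Extending an Ether Chain with an Amine Terminus

The source may hold more compounds than are shown below. What is called first, only, known or untested is meant among the compounds shown, and "the series" means these compounds.

Measured so far, in a functional assay on MIA PaCa-2 cells (Homo sapiens) for inhibition, read by MTT assay, with a stated time of 72 h; on this read-out lower numbers stand for stronger inhibition and higher numbers for weaker inhibition:
- compound 1 `O=C(Nc1cccc2cccnc12)c1ncccn1`: compound 1 gives 330 nM
- compound 2 `COc1cc(NC(=O)c2ncccn2)c2ncccc2c1`: compound 2 gives 1300 nM

Compound 2 stands highest of the two numbers in this assay, its nearest neighbour being compound 1, reached by a 3.9-fold higher number from compound 1 to compound 2 (0.60 log units; beyond the scatter), a modest step linked to a methoxy in place of hydrogen on an aromatic carbon.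

Compound 3 `NCCOc1cc(NC(=O)c2ncccn2)c2ncccc2c1` differs from compound 2 by aminomethyl in place of hydrogen on a saturated chain carbon bound to an oxygen on an aromatic ring; seen one bond further out, the methoxy of compound 2 becomes a 2-aminoethoxy in compound 3.

For the measured compounds named here, no measured step covers this kind of change. Going by the values given here, the only step available, a 3.9-fold higher number from compound 1 to compound 2 (0.60 log units; beyond the scatter), concerns placing the ether group itself on the ring, not lengthening its chain, so it gives no direct guide to what happens when the chain grows. With nothing more to go on, the expectation for compound 3 in this assay is a step no larger than the scatter, no change at the digits printed from compound 2 to compound 3 (within the scatter), though the uncertainty is wide.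

Compound 3 is therefore estimated at 1300 nM, in a range from 400 nM to 4500 nM.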

Compound 3, half-maximal inhibitory concentration: > 10000 nM
Compound 3 was reported as a limit; the forecaster's own chance of this, stated with the estimate: 5%; middle value at least 7.6-fold (0.88 log units) away from the limit.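

In this assay, compound 3 gives a limit of the assay rather than a number: the limit of > 10000 nM in this assay, at which 1 of the 3 values shown sits.

Even as a limit, the result has a clear direction: growing the methoxy into a 2-aminoethoxy gives an at least 7.6-fold higher number from compound 2 to compound 3 (0.88 log units; beyond the scatter), so this position does not simply tolerate a longer ether chain with an amine at its end. Measured against hydrogen on the same aromatic carbon, the 2-aminoethoxy gives an at least 30-fold higher number from compound 1 to compound 3 (1.48 log units; beyond the scatter), a large step, while the methoxy gave only a 3.9-fold higher number from compound 1 to compound 2 (0.60 log units; beyond the scatter), so on this read-out the longer group carries the greater loss of the two.

The three compounds cannot separate the effect of the extra chain from that of the amine, and an ethoxy group, which has the chain without the amine, or a 2-hydroxyethoxy group, which ends in a hydroxyl instead, would help to pull the two apart. Going by these compounds, whether a longer chain or a dimethylamino group at the chain end would behave in the same way also remains open.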